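Amino Group Replaces Aryl at the Carbonyl of Compound 2

The compounds below may be only part of what the source reports. "The series", "measured", "known", "first", "only" and "open" are said of these compounds alone.

Compound 1 `COc1cc(-c2nnc(SCC(=O)c3ccc(Br)cc3)n2N)cc(OC)c1OC`: 10400 nM in a functional assay on HeLa cells (Homo sapiens) for antiproliferative activity, read by MTT assay, with a stated time of 48 h; a higher number here means a weaker inhibitor, a lower number a stronger inhibitor
Compound 2 `COc1cc(-c2nnc(SCC(=O)c3ccc(F)cc3)n2N)cc(OC)c1OC`: 20900 nM
Compound 3 `COc1cc(-c2nnc(SCC(=O)Nc3ccccc3)n2N)cc(OC)c1OC`: 8280 nM

Among these three, compound 2 gives the highest number, with compound 1 within the scatter of it (a 2.0-fold higher number from compound 1 to compound 2 (0.30 log units; within the scatter)) and compound 3 modestly lower (a 2.5-fold lower number from compound 2 to compound 3 (0.40 log units; beyond the scatter)). Compound 4 `COc1cc(-c2nnc(SCC(=O)NCc3ccc(Cl)cc3)n2N)cc(OC)c1OC` differs from compound 2 by (4-chlorobenzyl)amino in place of 4-fluorophenyl on a carbonyl carbon. The closest measured guide is the step from compound 2 to compound 3, where an amino group entering at the carbonyl carbon gave a modest lowering; the halogen swap between compound 1 and compound 2 stayed within the scatter. Compound 4 is therefore expected to give a modestly lower number, a 2.3-fold lower number from compound 2 to compound 4 (0.37 log units; beyond the scatter). Compound 4 is estimated at 9000 nM, with a range from 4000 nM to 20000 nM.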

Compound 4, half-maximal inhibitory concentration: > 100000 nM
Compound 4: no number, only a limit; the forecaster's own chance of this, stated with the estimate: 5%; middle value at least 11-fold (1.04 log units) from the limit.
By their numbers in this assay, from the lowest: compounds 3, 1 and 2 (each within the scatter of the next, the first and the last beyond it). At a limit, above all of these: compound 4.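

In this assay compound 4 gives no number, only a limit of the assay: the limit of > 100000 nM in this assay, at which 1 of the 4 values shown sits.

An amino group at the carbonyl carbon therefore does not by itself lower the number, as compound 3 alone suggested; what the nitrogen carries decides the direction. Read as minimum sizes, an at least 12-fold higher number from compound 3 to compound 4 (1.08 log units; beyond the scatter) is large, and an at least 4.7-fold higher number from compound 2 to compound 4 (0.67 log units; beyond the scatter) and an at least 9.6-fold higher number from compound 1 to compound 4 (0.98 log units; beyond the scatter) point the same way.

It remains open whether the chlorine or the extra chain carbon of the 4-chlorobenzyl group accounts for this, since an unsubstituted benzylamino group and a 4-chloroanilino group are not among the compounds shown.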